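Hydroxy for methoxy on the 3-substituted aryl hydrazone

The compounds below may be only part of what the source reports. "The series", "measured", "known", "first", "only" and "open" are said of these compounds alone.

Compound 1 `O=C(N/N=C/c1ccc(O)cc1)c1ccc(-c2nc3ccccc3s2)cc1`, compound 2 `COc1ccc(/C=N/NC(=O)c2ccc(-c3nc4ccccc4s3)cc2)cc1` and compound 3 `COc1cccc(/C=N/NC(=O)c2ccc(-c3nc4ccccc4s3)cc2)c1` share one core and differ only in the aryl group on the carbon with a double bond to nitrogen; compound 4 `O=C(N/N=C/c1cccc(O)c1)c1ccc(-c2nc3ccccc3s2)cc1` has not yet been measured. In an assay on isolated protein for inhibition of Maltase-glucoamylase (Homo sapiens), with a stated time of 15 min (on this read-out higher numbers stand for weaker inhibition and lower numbers for stronger inhibition), compound 1 gives 11300 nM. In this assay compound 2 gives 18300 nM, and compound 3 gives 11100 nM.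

The change of hydrogen in place of methyl on an oxygen on an aromatic ring made the step of a 1.6-fold lower number from compound 2 to compound 1 (0.21 log units; within the scatter). The two cores of compound 2 and compound 3 differ by 3-methoxyphenyl in place of 4-methoxyphenyl on a carbon with a double bond to nitrogen, with the step of a 1.6-fold lower number from compound 2 to compound 3 (0.22 log units; within the scatter). Between compound 1 and compound 3 the step is a 1.0-fold lower number from compound 1 to compound 3 (0.01 log units; within the scatter). All three numbers sit within the scatter of one another, so no order among them can be read from these data.

Compound 4 arises from compound 3 by hydrogen in place of methyl on an oxygen on an aromatic ring, which is the same change, at the same place, as that from compound 2 to compound 1. Since that earlier step of a 1.6-fold lower number from compound 2 to compound 1 (0.21 log units; within the scatter) stayed within the scatter, the step from compound 3 to compound 4 is expected to be small as well, estimated at a 1.2-fold lower number from compound 3 to compound 4 (0.09 log units; within the scatter). The expectation for compound 4 therefore rests on one prior example only. Compound 4 is estimated at 9000 nM in this assay, with a range from 4000 nM to 20000 nM.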

Compound 4, half-maximal inhibitory concentration: 9210 nM
For compound 4 the middle estimate is 1.0-fold (0.01 log units) below the measured one, and the stated range covers the measured number.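

In this assay, hydrogen in place of methyl on an oxygen on an aromatic ring gives a 1.2-fold lower number from compound 3 to compound 4 (0.08 log units; within the scatter), and this can be set against the same change on the other core: the same change on two cores in this assay, a 1.6-fold lower number (0.21 log units; within the scatter) from compound 2 to compound 1 and a 1.2-fold lower number (0.08 log units; within the scatter) from compound 3 to compound 4, 1.3-fold (0.13 log units) apart, within the scatter of two such steps. The remaining steps to compound 4, a 2.0-fold lower number from compound 2 to compound 4 (0.30 log units; within the scatter) and a 1.2-fold lower number from compound 1 to compound 4 (0.09 log units; within the scatter), also stay within the scatter, so the four compounds cannot be put in any order by these values. Methoxy to hydroxy therefore carries from the 4-methoxyphenyl compound to the 3-methoxyphenyl compound with matching results, but each step is too small to show that the change has any real effect, and agreement between two closely related cores in one assay does not establish a rule for the wider series.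

The compounds shown leave open whether any group at this place on the aromatic ring can move the number beyond the scatter, for example an amine, a carboxylic acid or a longer chain such as butoxy in place of methoxy. They also leave open whether methoxy to hydroxy would behave the same way on a core changed elsewhere than in this aryl group.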